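A few compounds are considered here, and "the series" means these few. Any claim that something is new, unique, unknown or untested is made for them only; others in the source may bear on it.

Compound 1 `COc1ccc(F)cc1CNCCCNc1ccnc2cc(C3CCCCC3)ccc12` and compound 2 `CC(C)CCc1ccc2c(NCCCNCc3ccco3)ccnc2c1` have both been examined in an ADME assay on HepG2 cells (Homo sapiens) for cytotoxicity, read by luminescence, CellTiter-Glo and ATP content, with a stated time of 72 h; a lower number here means that less compound is needed, a higher number that more compound is needed for the effect. In this assay compound 1 gives 2290 nM, while compound 2 gives 11200 nM; of these two numbers, that of compound 1 is the lower, and the gap between them lies beyond the usual scatter. Compound 1 and compound 2 differ in more than one place. No single step can be read from that pair. Compound 3 `COc1ccc(F)cc1CNCCCNc1ccnc2cc(CC(C)C)ccc12` has not yet been measured in this assay. It differs from compound 1 in one place: isobutyl in place of cyclohexyl on an aromatic carbon. Going by the values given here, no measured pair shows the effect of this change on its own. Given that compound 2 gives 11200 nM, a somewhat higher number than that of compound 1 is expected for compound 3, as a step of a 1.5-fold higher number from compound 1 to compound 3 (0.18 log units; within the scatter) of modest size, near the edge of the scatter. Compound 3 is estimated at 3500 nM, with a range from 1500 nM to 9000 nM.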

Compound 3, half-maximal effective concentration: 2900 nM
The estimate for compound 3 lay 1.2-fold (0.08 log units) above the measured number; the range from low to high includes it.
By their numbers in this assay, from the lowest: compounds 1 and 3 (each within the scatter of the next); then compound 2.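

In this assay, going by these compounds alone, isobutyl in place of cyclohexyl on this aromatic carbon gives a 1.3-fold higher number from compound 1 to compound 3 (0.10 log units; within the scatter) and so provides the first reading of a single change at this position. In this pair, the six-membered non-aromatic ring of carbon only can give way to an open chain with fewer heavy atoms, and the two numbers stay within the usual scatter of each other. Nothing available gives a measured explanation for this result.

Going by these compounds, whether this position would accept very different groups, such as an amine, a carboxylic acid or a longer chain, remains open. On these data alone, it is also open whether the same exchange would give a similar step with another group on the side chain, as this reading rests on a single pair.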